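From benzyloxy to (4-bromobenzyl)oxy on the shared core

The source may hold more compounds than are shown below. What is called first, only, known or untested is meant among the compounds shown, and "the series" means these compounds.

In a functional assay on HT-29 cells (Homo sapiens) for inhibition, read by MTT assay, with a stated time of 3 days (a higher number here means a weaker inhibitor, a lower number a stronger inhibitor), compound 1 `C=CCOc1cc(/C=C\c2cc(OC)c(OC)c(OC)c2)ccc1OC` gives 29000 nM, compound 2 `C/C=C/COc1cc(/C=C\c2cc(OC)c(OC)c(OC)c2)ccc1OC` gives 161000 nM and compound 3 `COc1ccc(/C=C\c2cc(OC)c(OC)c(OC)c2)cc1OCc1ccccc1` gives 39000 nM. Compound 3 sits with compound 1 at the stronger end of these three numbers: a 1.3-fold higher number from compound 1 to compound 3 (0.13 log units; within the scatter), and a 4.1-fold lower number from compound 2 to compound 3 (0.62 log units; beyond the scatter). Compound 4 `COc1ccc(/C=C\c2cc(OC)c(OC)c(OC)c2)cc1OCc1ccc(Br)cc1` carries (4-bromobenzyl)oxy in place of benzyloxy: bromo in place of hydrogen on an aromatic carbon. Within the data shown here, the remaining measured step, a 5.6-fold higher number from compound 1 to compound 2 (0.74 log units; beyond the scatter), also changes only the group on the chain carbon, so no measured step tests bromo in place of hydrogen on an aromatic carbon. The expectation therefore rests on compound 3 at 39000 nM. The expected change is small, a 1.1-fold lower number from compound 3 to compound 4 (0.03 log units; within the scatter), with no firm direction. Compound 4 is estimated at 36000 nM, within an expected range of 12000 nM to 100000 nM.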

Compound 4, half-maximal inhibitory concentration: 108000 nM
For compound 4 the middle estimate is 3.0-fold (0.48 log units) below the measured one; measured number outside the range, above it.
By their numbers in this assay, from the lowest: compounds 1 and 3 (each within the scatter of the next); then compounds 4 and 2 (each within the scatter of the next).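

In this assay, the benzyloxy ring does not tolerate every substitution: bromo in place of hydrogen, para to a large group, gives a 2.8-fold higher number from compound 3 to compound 4 (0.44 log units; beyond the scatter) and so weakens inhibition beyond the scatter. The (4-bromobenzyl)oxy group also separates from vinyl, with a 3.7-fold higher number from compound 1 to compound 4 (0.57 log units; beyond the scatter) on that side, while a 1.5-fold lower number from compound 2 to compound 4 (0.17 log units; within the scatter) leaves it within the scatter of prop-1-en-1-yl. No measured evidence bears on the origin of this bromo step.

As far as these compounds go, what chloro, methoxy or an amine would give in place of bromo stays open. So does the effect of a longer chain on the oxygen.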